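The source may hold more compounds than are shown below. What is called first, only, known or untested is meant among the compounds shown, and "the series" means these compounds.

In a functional assay on COLO 320 cells (Homo sapiens) for cytotoxicity, read by colony formation (on this read-out lower numbers stand for stronger inhibition and higher numbers for weaker inhibition), compound 1 `CCC(=O)OC[C@H]1O[C@@H](O[C@@H]2OC=C(C(=O)OC)[C@H]3C[C@H](OC(C)=O)[C@H](C)[C@@H]23)[C@H](OC(C)=O)[C@@H](OC(C)=O)[C@@H]1OC(C)=O` gives 4.86 ug/mL and compound 2 `COC(=O)C1=CO[C@@H](O[C@@H]2O[C@H](COC(=O)C=C(C)C)[C@@H](OC(C)=O)[C@H](OC(C)=O)[C@H]2OC(C)=O)[C@@H]2[C@@H](C)[C@@H](OC(C)=O)C[C@H]12` gives 2.84 ug/mL. These two numbers lie within the scatter of each other, so compound 2 stands level with compound 1. Compound 3 `COC(=O)C1=CO[C@@H](O[C@@H]2O[C@H](COC(=O)c3cccc([N+](=O)[O-])c3)[C@@H](OC(C)=O)[C@H](OC(C)=O)[C@H]2OC(C)=O)[C@@H]2[C@@H](C)[C@@H](OC(C)=O)C[C@H]12` keeps the shared core and differs from compound 2 in one place: 3-nitrophenyl in place of 2-methylprop-1-en-1-yl on a carbonyl carbon. In words, 3-nitrophenyl takes the place of 2-methylprop-1-en-1-yl on a carbonyl carbon, bringing in one six-membered aromatic ring of carbon only. Among the measured compounds shown here, the one measured step that bears on this is a 1.7-fold lower number from compound 1 to compound 2 (0.23 log units; within the scatter), on the same carbonyl carbon. It is a single swap and includes no aromatic group, so it is only a weak guide. The expected change is therefore small and without a firm direction, an estimated 1.2-fold higher number from compound 2 to compound 3 (0.09 log units; within the scatter). For compound 3 the estimated value is 3.5 ug/mL, with an expected range from 1.4 ug/mL to 9 ug/mL.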

Compound 3, half-maximal inhibitory concentration: 8.2 ug/mL
For compound 3 the middle estimate is 2.3-fold (0.37 log units) below the measured one; the measured number falls inside the stated range.
By their numbers in this assay, from the lowest: compounds 2, 1 and 3 (each within the scatter of the next, the first and the last beyond it).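

In this assay, among the compounds shown here, the swap of 2-methylprop-1-en-1-yl for 3-nitrophenyl on this carbonyl carbon gives a 2.9-fold higher number from compound 2 to compound 3 (0.46 log units; beyond the scatter) and is the first step at this position to clear the usual scatter, though only modestly. Set against ethyl, the same aromatic group gives a 1.7-fold higher number from compound 1 to compound 3 (0.23 log units; within the scatter) so the ethyl compound stands level with both of the others, and only the two larger groups can be told apart here. Nothing measured here accounts for the difference between them.

On these data alone, it remains open whether the step follows from the aromatic ring itself or from its nitro group, a question that a plain phenyl on the same carbonyl carbon would address. As far as these compounds go, how a longer alkyl chain or an amine would behave at this position is also open.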